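From phenyl to 3-chlorophenyl in compound 2

The compounds below may be only part of what the source reports. "The series", "measured", "known", "first", "only" and "open" are said of these compounds alone.

Values so far in a functional assay on HepG2 cells (Homo sapiens) for antiproliferative activity, read by CCK-8 assay, with a stated time of 72 h (on this read-out higher numbers stand for weaker inhibition and lower numbers for stronger inhibition), are these:
- compound 1 `Nc1ccccc1NC(=O)c1ccc(COCNc2nc(Nc3ccccc3)c3ncn(C4CCCC4)c3n2)cc1` gives 6020 nM here
- compound 2 `CCCCn1cnc2c(Nc3ccccc3)nc(NCOCc3ccc(C(=O)Nc4ccccc4N)cc3)nc21` gives 4090 nM here

Among the compounds with values here, compound 2 has only compound 1 to be set against, and the single measured step, a 1.5-fold lower number from compound 1 to compound 2 (0.17 log units; within the scatter), does not separate the two. Their numbers cannot be put in order.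

Compound 3 `CCCCn1cnc2c(Nc3cccc(Cl)c3)nc(NCOCc3ccc(C(=O)Nc4ccccc4N)cc3)nc21` differs from compound 2 in one place. It carries chloro in place of hydrogen on an aromatic carbon, (chloro in place of hydrogen on an aromatic carbon), so that phenyl becomes 3-chlorophenyl and anilino becomes (3-chlorophenyl)amino.

Within the data shown here, no measured step speaks directly to this change. Among the measured compounds shown here, the step above, a 1.5-fold lower number from compound 1 to compound 2 (0.17 log units; within the scatter), concerns butyl and cyclopentyl on an aromatic nitrogen, and no chloro compound has been measured. The data thus give no firm direction, and no shift beyond the scatter is expected in this assay for this change. The step expected is a 1.3-fold lower number from compound 2 to compound 3 (0.11 log units; within the scatter) and the range around it stays wide. For compound 3 the estimated value is 3200 nM with an expected range from 1100 nM to 9000 nM in this read-out.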

Compound 3, half-maximal inhibitory concentration: 8660 nM
For compound 3 the middle estimate is 2.7-fold (0.43 log units) below the measured one; the measured number falls inside the stated range.
By their numbers in this assay, from the lowest: compounds 2, 1 and 3 (each within the scatter of the next, the first and the last beyond it).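

In this assay, chloro in place of hydrogen on an aromatic carbon, meta to a large group, is a change that registers beyond the scatter (a 2.1-fold higher number from compound 2 to compound 3 (0.33 log units; beyond the scatter)), and the step is a modest one. Within the data shown here, the only earlier step concerned butyl and cyclopentyl on an aromatic nitrogen and left the anilino group untouched, whereas this pair shows that the number responds to a single added atom on that group, and that with butyl on the nitrogen the move from phenyl to 3-chlorophenyl goes towards weaker inhibition. The direction rests on this one pair, and nothing at hand explains the shift.

The compounds shown do not tell whether the shift belongs to chloro itself or to any group at this carbon, a question that a fluoro, a methoxy, an amine or a carboxylic acid in the same place would address. They also leave open whether 3-chlorophenyl would move the number in the same direction with cyclopentyl on the aromatic nitrogen, and whether chloro on another carbon of the same ring would do so.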